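Halogen swap on the phenoxy ring: lipophilicity notes

The source may hold more compounds than are shown below. What is called first, only, known or untested is meant among the compounds shown, and "the series" means these compounds.

Measured so far in a physicochemical assay for lipophilicity, in phosphate buffer, measured as octanol-water partition, with a stated time of 24 h; a lower number here means a more polar compound, a higher number a more lipophilic compound:
- compound 1 `Cc1ccc(Oc2ccc(/C=N/Nc3nc4ccccc4s3)cc2)cc1` gives 5.4
- compound 2 `O=C(CSc1nc2ccccc2s1)N/N=C/c1ccc(Oc2ccc(Cl)cc2)cc1` gives 5.6
- compound 3 `O=C(CSc1nc2ccccc2s1)N/N=C/c1ccc(Oc2ccc(F)cc2)cc1` gives 5.5

Compound 3 holds the second highest of the three numbers. Its nearest neighbour is compound 1, whose value lies within the scatter of that of compound 3, and its furthest is compound 2, whose value likewise lies within the scatter. The three values therefore sit in one narrow band, and no order among them can be read from these data.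

The next member, compound 4 `O=C(CSc1nc2ccccc2s1)N/N=C/c1ccc(Oc2ccc(Br)cc2)cc1`, differs from compound 3 in one place: bromo in place of fluoro on an aromatic carbon.

Among the compounds with values here, one measured step bears on this change. Going from a chloro group to a fluoro group on the same aromatic carbon gave a number 0.10 log units lower from compound 2 to compound 3 (within the scatter). Replacing fluoro by bromo reverses that direction and goes one halogen further, so in this assay a step upward of about the same small size, or a little larger, is expected, most likely still within the scatter.

For compound 4 the estimated step is a number 0.20 log units higher from compound 3 to compound 4 (within the scatter). The expected value for compound 4 is 5.7, with a range from 5.4 to 6.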

Compound 4, partition coefficient: 5.7
Beside the measured number, compound 4's estimate shows no gap at the digits printed; low and high end bracket the measured number.
By their numbers in this assay, from the lowest: compounds 1, 3, 2 and 4 (each within the scatter of the next).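

In this assay, the 4-fluorophenoxy to 4-bromophenoxy exchange gives a number 0.20 log units higher from compound 3 to compound 4 (within the scatter), and the exchange of chloro for bromo at the same aromatic carbon gives a number 0.10 log units higher from compound 2 to compound 4 (within the scatter). With bromo included, three halogens have now been read at this place, para to a large group, and each of the three steps among compound 2, compound 3 and compound 4 lies within the scatter, so this read-out does not separate these halogens and no order among them can be stated. No measured evidence accompanies these numbers to account for this narrow band, and none is offered here.

The compounds shown leave open whether any group at this aromatic carbon can produce a step beyond the scatter, as the three direct comparisons cover halogens only, and an amine, a carboxylic acid or a longer chain such as a butoxy group would test that directly. Also open is whether the same halogen exchange stays this small on the core of compound 1, where no halogen-bearing partner is shown.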